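This account rests on a few compounds, and the source may have more. Where it says the series, first, only, none or still open, it means among the compounds named here.

Measured in an ADME assay on MT4 cells (Homo sapiens) for cytotoxicity, read by MTT assay; on this read-out higher numbers stand for lower toxicity in this test and lower numbers for higher toxicity in this test:
- Compound 1 `O=C1c2ccccc2C(=O)N1CCOC(=S)N(C(=O)c1ccccc1[N+](=O)[O-])c1ccc(Cl)cc1`: 21000 nM
- Compound 2 `COc1cccc(OC)c1C(=O)N(C(=S)OCCN1C(=O)c2ccccc2C1=O)c1ccc(Cl)cc1`: 69000 nM
- Compound 3 `O=C1c2ccccc2C(=O)N1CCOC(=S)N(C(=O)c1ccc([N+](=O)[O-])cc1Cl)c1ccc(Cl)cc1`: 19000 nM

Compound 3 shares the low end of these numbers, and its gap to the nearest value is small: a 1.1-fold lower number from compound 1 to compound 3 (0.04 log units; within the scatter). The gap to the furthest value is larger: a 3.6-fold lower number from compound 2 to compound 3 (0.56 log units; beyond the scatter).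

Compound 4 `O=C1c2ccccc2C(=O)N1CCOC(=S)N(C(=O)c1cccc2ccccc12)c1ccc(Cl)cc1` carries naphthalen-1-yl in place of 2-chloro-4-nitrophenyl on a carbonyl carbon. Within the data shown here, no measured compound carries this group, so the evidence is indirect. Among the measured compounds shown here, the steps that bear on it are the other exchanges at the same carbonyl carbon. Between the two groups bearing a nitro group, the number did not move beyond the scatter: a 1.1-fold lower number from compound 1 to compound 3 (0.04 log units; within the scatter). For the measured compounds named here, the one group without a nitro group gave a modest rise: a 3.3-fold higher number from compound 1 to compound 2 (0.52 log units; beyond the scatter). Naphthalen-1-yl also has no nitro group, but that comparison rests on compound 2 alone. A small rise in this assay therefore seems likelier than a fall, though it may not clear the scatter. The expected change is a 1.7-fold higher number from compound 3 to compound 4 (0.23 log units; within the scatter). For compound 4 the estimate is 32000 nM, with an expected range from 12000 nM to 85000 nM.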

Compound 4, half-maximal cytotoxic concentration: 6000 nM
The estimate for compound 4 lay 5.3-fold (0.73 log units) above the measured number; the measured number lies below the stated range.
By their numbers in this assay, from the lowest: compound 4; then compounds 3 and 1 (each within the scatter of the next); then compound 2.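

Compound 4 shows that, in this assay, this carbonyl carbon, whose other neighbour is the amide-type nitrogen, can also give a clearly lower number than the nitro-bearing groups, with naphthalen-1-yl in place of 2-chloro-4-nitrophenyl giving a modest fall (a 3.2-fold lower number from compound 3 to compound 4 (0.50 log units; beyond the scatter)) and a similar one in place of 2-nitrophenyl (a 3.5-fold lower number from compound 1 to compound 4 (0.54 log units; beyond the scatter)). The earlier compounds had shown the only group without a nitro group at the high end, but that link does not hold: compound 2 and compound 4 both lack a nitro group, yet they stand furthest apart, in a large step (a 12-fold lower number from compound 2 to compound 4 (1.06 log units; beyond the scatter)), so the range at this position is wider than the first three compounds had revealed. Nothing available here accounts for this fall in the number.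

The compounds shown leave open whether the lower number goes with the second aromatic ring of naphthalen-1-yl or with the absence of the nitro group and the chlorine. An unsubstituted phenyl or a naphthalen-2-yl group at the same carbonyl carbon would help to separate these readings.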